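This account rests on a few compounds, and the source may have more. Where it says the series, first, only, none or still open, it means among the compounds named here.

Measured compounds in a functional assay on MCF7 cells (Homo sapiens) for antiproliferative activity, read by MTT assay, with a stated time of 48 h, tested at 50 uM; on this read-out lower numbers stand for a stronger effect and higher numbers for a weaker effect at the one concentration tested:

- compound 1, `OC(CCn1nc2c(Br)c(Br)c(Br)c(Br)c2n1)c1ccc(F)cc1`, gives 7%
- compound 2, `OC(CCn1nc2c(Br)c(Br)c(Br)c(Br)c2n1)c1ccccc1`, gives 23%
- compound 3, `OC(CCn1nc2c(Br)c(Br)c(Br)c(Br)c2n1)c1ccc(Br)cc1`, gives 15%

Compound 1 holds the lowest of these three numbers, which on this read-out means the strongest effect. The step of a number 8 percentage points higher from compound 1 to compound 3 (within the scatter) stays within the scatter, whereas a number 16 percentage points higher from compound 1 to compound 2 (beyond the scatter) goes beyond it.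

Compound 4, `OC(CCn1nc2c(Br)c(Br)c(Br)c(Br)c2n1)c1ccc(Cl)cc1`, differs from compound 1 in one place: chloro in place of fluoro on an aromatic carbon. Going by the values given here, two measured steps bear on this. Exchanging fluoro for bromo at the same carbon gave a number 8 percentage points higher from compound 1 to compound 3 (within the scatter), and removing fluoro altogether gave a number 16 percentage points higher from compound 1 to compound 2 (beyond the scatter). Chloro resembles the first exchange more than the second, so no step beyond the scatter is expected in this assay, at most a slight rise.

In this assay compound 4 is expected to give about 11%, within a range from 3% to 22%. The expected step is a number 4 percentage points higher from compound 1 to compound 4 (within the scatter).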

Compound 4, a percentage reported as activity, at one concentration (the size of the read-out at that concentration, not a potency): 9%
Compound 4: the middle estimate sits 2 percentage points above what was measured; the measured number falls inside the stated range.
By their numbers in this assay, from the lowest: compounds 1, 4, 3 and 2 (each within the scatter of the next, the first and the last beyond it).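

In this assay, both a number 2 percentage points higher from compound 1 to compound 4 (within the scatter) and a number 6 percentage points lower from compound 3 to compound 4 (within the scatter) stay within the scatter, so chloro cannot be told apart from fluoro or bromo at this position. The step of a number 14 percentage points lower from compound 2 to compound 4 (beyond the scatter) shows that chloro, like fluoro, separates from hydrogen here, although the bromo of compound 3 goes against this pattern by staying within the scatter of compound 2. Nothing measured here offers an explanation for these results. The compounds shown leave open how an amine, a carboxylic acid or a methoxy group would read at this position.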